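From 3-chlorophenyl to 2-chlorophenyl on compound 1

This account rests on a few compounds, and the source may have more. Where it says the series, first, only, none or still open, it means among the compounds named here.

In a functional assay on HCT-116 cells (Homo sapiens) for antiproliferative activity, read by MTT assay, with a stated time of 72 h (a lower number here means a stronger inhibitor, a higher number a weaker inhibitor), compound 1 `NC1=NC2(CCSCC2)N(OCCCOc2cccc(Cl)c2)C(N)=N1` gives 1 nM, the lowest of the three numbers. Compound 2 `NC1=NC2(CCOCC2)N(OCCCOc2ccc(Cl)cc2)C(N)=N1` gives 690 nM and compound 3 `NC1=NC2(CCOCC2)N(OCCCOc2ccc(Cl)cc2Cl)C(N)=N1` gives 880 nM, both far beyond the scatter from compound 1. Compound 4 `NC1=NC2(CCSCC2)N(OCCCOc2ccccc2Cl)C(N)=N1` carries 2-chlorophenyl in place of 3-chlorophenyl on an oxygen on a saturated carbon. Within the data shown here, the only measured step involving a ring chlorine, chloro in place of hydrogen on an aromatic carbon, is a 1.3-fold higher number from compound 2 to compound 3 (0.11 log units; within the scatter). It is a different change on a different core, so it is only a weak guide. Among the measured compounds shown here, no measured step moves a chlorine on the core of compound 1. A moderate rise toward weaker inhibition is expected, with an estimated step of a 10-fold higher number from compound 1 to compound 4 (1.00 log units; beyond the scatter). Compound 4 is estimated at 10 nM, with an expected range from 1 nM to 100 nM.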

Compound 4, half-maximal inhibitory concentration: 1 nM
Compound 4: middle estimate off by 10-fold (1.00 log units), on the high side; the measured number falls inside the stated range.
By their numbers in this assay, from the lowest: compounds 1 and 4 (each within the scatter of the next); then compounds 2 and 3 (each within the scatter of the next).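

Within this assay the change from 3-chlorophenyl to 2-chlorophenyl gives no change at the digits printed from compound 1 to compound 4 (within the scatter) on the core of compound 1. On this core, the phenyl on the oxygen thus carries its chlorine in either of these two placements with no separation in the numbers, which the earlier step, an added chlorine on another core, could not show. No evidence is available that bears on this result. Still open, going by these compounds, is whether an amine or a methoxy group in place of the chlorine would give the same reading, and whether the same swap would read alike on the core of compound 2.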